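Cytotoxicity notes: aryl group exchange on the shared core

The source may hold more compounds than are shown below. What is called first, only, known or untested is meant among the compounds shown, and "the series" means these compounds.

Measured so far in an ADME assay on MT2 cells (Homo sapiens) for cytotoxicity; a higher number here means that more compound is tolerated, a lower number that less compound is tolerated:
Compound 1 `CC1(C)OC(=O)C2(C(=O)O1)[C@@H](c1ccco1)CC(=O)C[C@H]2c1c[nH]c2ccccc12` gives > 111000 nM, which is a limit of the assay.
Compound 2 `CC1(C)OC(=O)C2(C(=O)O1)[C@@H](c1ccco1)CC(=O)C[C@H]2c1ccc(Br)cc1` gives > 111000 nM, likewise a limit.
Compound 3 `COc1cc([C@@H]2CC(=O)C[C@H](c3ccco3)C23C(=O)OC(C)(C)OC3=O)ccc1O` gives > 111000 nM, again a limit.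

Compound 1 therefore stands at the assay limit, and the same holds for the two other values shown, as recorded in the limit of > 111000 nM in this assay, at which 3 of the 3 values shown sit. The steps a step that the two limits leave unreadable from compound 1 to compound 2, a step that the two limits leave unreadable from compound 1 to compound 3 and a step that the two limits leave unreadable from compound 2 to compound 3 are all unreadable in size, since both ends of each sit at the limit.

Compound 4 `COc1ccc([C@@H]2CC(=O)C[C@H](c3ccco3)C23C(=O)OC(C)(C)OC3=O)cc1OC` is not yet measured. The change 3,4-dimethoxyphenyl in place of 1H-indol-3-yl on a saturated ring carbon keeps the rest of the core unchanged. For the measured compounds named here, no measured step bears readably on it, so no direction can be drawn from the data. Given that three aryl variants at this position all reach the limit, compound 4 is expected to do the same; the expected step that the limit leaves unreadable from compound 1 to compound 4 is none beyond the scatter. Compound 4 is estimated at 150000 nM, within 70000 nM to 400000 nM, most likely reported only as a limit.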

Compound 4, half-maximal cytotoxic concentration: > 111000 nM
Compound 4 was reported as a limit; the forecaster's own chance of this, stated with the estimate: 85%; the middle value lies beyond the limit too.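

The steps linking compound 4 with compound 1, compound 2 and compound 3 cannot be read in this assay as both ends of each sit at a limit: the limit of > 111000 nM in this assay, at which 4 of the 4 values shown sit.

The compounds shown leave open whether any aryl exchange on the shared core would give a number rather than a limit in this assay and how large such a step would be.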